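Swapping the Aryl Amide Cap in a Fluorinated Hydroxamate Series

This account rests on a few compounds, and the source may have more. Where it says the series, first, only, none or still open, it means among the compounds named here.

Compound 1, `O=C(NO)C(F)(F)C(F)(F)C(F)(F)C(F)(F)C(F)(F)C(F)(F)C(=O)Nc1ccc(I)cc1`, gives 4100 nM in an assay on isolated protein for inhibition of histone deacetylase 7 (Homo sapiens), read by fluorescence; on this read-out lower numbers stand for tighter binding and higher numbers for weaker binding.
Compound 2, `O=C(NO)C(F)(F)C(F)(F)C(F)(F)C(F)(F)C(F)(F)C(F)(F)C(=O)Nc1nc(-c2ccccc2)cs1`, gives 1400 nM in this assay.

Both measured compounds share one core: a hydroxamic acid at one end of a fully fluorinated chain, with an amide at the other end whose nitrogen carries an aromatic group. Within the data shown here, only that aromatic group differs between them, and the single measured step, a 2.9-fold lower number from compound 1 to compound 2 (0.47 log units; beyond the scatter), puts compound 2 at the lower, tighter-binding number of the two, with compound 1 the only neighbour for comparison.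

Compound 3, `O=C(NO)C(F)(F)C(F)(F)C(F)(F)C(F)(F)C(F)(F)C(F)(F)C(=O)Nc1ccccc1-c1ccccc1`, keeps the same core and changes just the aromatic group again: 2-phenylphenyl in place of 4-phenyl-1,3-thiazol-2-yl on an amide-type nitrogen. Among the measured compounds shown here, the one step available shows that swapping this group can shift the number by a modest amount. For the measured compounds named here, no measured pair involves the 2-phenylphenyl group, so the direction for compound 3 cannot be read from the data; the new group is closer in kind to the plain benzene-type cap of compound 1 than to the thiazole cap of compound 2.

Compound 3 is therefore expected to fall between the two measured values, a step of a 1.8-fold higher number from compound 2 to compound 3 (0.25 log units; within the scatter). The estimate for compound 3 is 2500 nM, with a range from 800 nM to 8000 nM.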

Compound 3, dissociation constant: 14000 nM
For compound 3 the middle estimate is 5.6-fold (0.75 log units) below the measured one, and the stated range ends below it.
By their numbers in this assay, from the lowest: compound 2; then compound 1; then compound 3.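

In this assay, the group on the amide nitrogen proves able to move the number further than the first step suggested: the change to 2-phenylphenyl gives a 10-fold higher number from compound 2 to compound 3 (1.00 log units; beyond the scatter) and also a 3.4-fold higher number from compound 1 to compound 3 (0.53 log units; beyond the scatter), which leaves compound 3 with the highest number of the three, beyond the scatter from both others. The step from compound 2 to compound 3 also shows that similar counts do not guarantee similar numbers, since 4-phenyl-1,3-thiazol-2-yl and 2-phenylphenyl have close heavy-atom counts, and each has two aromatic rings, yet the two compounds lie clearly apart. No measurement given here explains why this change raises the number.

The entering group differs from the leaving one in its ring types, in its lack of nitrogen and sulfur, and in its hydrogen-bond acceptor count, and these three compounds cannot show which of these differences matters. They also leave open how the number would respond to an amine or a carboxylic acid placed on the aromatic group, or to a longer chain in the shared core.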